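Fluoro for tert-butyl: cytotoxicity on Vero cells

The source may report more compounds than this note shows. Statements on the series, on what has been measured and on what is new or still open speak of the compounds shown alone.

Measured compounds:
compound 1 `CN(C)c1cc2[nH]c(C3CCCCC3)nc2cc1NC(=O)c1ccc(C(C)(C)C)cc1` — > 100 ug/mL
compound 2 `CCOCCOC(=O)Nc1cc2nc(C3CCCCC3)[nH]c2cc1N1CCCC1` — > 100 ug/mL

In an ADME assay on Vero cells (Chlorocebus sabaeus) for cytotoxicity, read by resazurin assay, with a stated time of 3 days (on this read-out lower numbers stand for stronger inhibition and higher numbers for weaker inhibition), compound 1 gives > 100 ug/mL; this value is a limit of the assay rather than a number. Compound 2 gives > 100 ug/mL in this assay, again a limit. Among the compounds with values here, both compounds share a core and both sit at the limit of > 100 ug/mL in this assay, at which 2 of the 2 values shown sit, so no step between measured compounds can be read here.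

Compound 3 `CN(C)c1cc2[nH]c(C3CCCCC3)nc2cc1NC(=O)c1ccc(F)cc1` is not yet measured. It differs from compound 1 by fluoro in place of tert-butyl on an aromatic carbon. Within the data shown here, with both measured values at the limit, there is no measured step to lean on, and the expectation for this assay is a step of no size beyond the usual scatter, in no particular direction: a number no higher from compound 1 to compound 3 (the limit leaves the size open). Compound 3 is therefore expected to give about 100 ug/mL, within the range 50 ug/mL to 200 ug/mL, most likely reported as a limit again.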

Compound 3, half-maximal inhibitory concentration: > 100 ug/mL
Compound 3: only a limit was reported; the forecaster's own chance of this, stated with the estimate: 75%; the middle value lies on the limit itself.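

In this assay, within the data shown here, compound 3 gives > 100 ug/mL and this is a limit of the assay, not a number, so no step from compound 1 to compound 3 can be read. Going by these compounds, what stays open is the concentration at which compound 1, compound 2 or compound 3 would harm these cells, and whether fluoro in place of tert-butyl changes that concentration at all.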